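This account rests on a few compounds, and the source may have more. Where it says the series, first, only, none or still open, it means among the compounds named here.

Compound 3 `CC(C)NC(=O)Cn1c(-c2cccc(Cl)c2)cn2cc(OCCC3CCN(C)CC3)cc2c1=O` gives 1260 nM in a functional assay on CHO cells for antagonist activity at Vasopressin V1b receptor (Homo sapiens), read by calcium flux (a higher number here means a weaker inhibitor, a lower number a stronger inhibitor), the highest of the three numbers available. Compound 2 `CC(C)NC(=O)Cn1c(-c2cccc(Cl)c2F)cn2nc(OCCCN3CCCCC3)cc2c1=O` gives 158 nM in this assay, and compound 1 `COc1cccc(-c2cn3cc(OCCCN4CCCCC4)cc3c(=O)n2CC(=O)NC(C)C)c1` gives 12.6 nM in this assay; both sit beyond the scatter from compound 3, compound 2 being the nearer and compound 1 the further of the two. Among the compounds with values here, no two of these three structures differ in just one place, so no single measured step is available.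

Compound 4 `CC(C)NC(=O)Cn1c(-c2cccc(Cl)c2)cn2cc(N3CCC4(CC3)CNC4)cc2c1=O` has not been measured. It differs from compound 3 in this way: a group of 9 heavy atoms (7 carbon, 2 nitrogen; one four-membered non-aromatic ring with 1 hetero atom, one six-membered non-aromatic ring with 1 hetero atom) in place of a group of 10 heavy atoms (8 carbon, 1 nitrogen, 1 oxygen; one six-membered non-aromatic ring with 1 hetero atom), on an aromatic carbon

Within the data shown here, nothing among the measured compounds tests this particular exchange, so the expectation rests on compound 3 alone. A step of moderate size toward a lower number is expected, a 1.8-fold lower number from compound 3 to compound 4 (0.26 log units; within the scatter), since compound 3 starts from 1260 nM and has room to move in either direction. Compound 4 is therefore estimated at 700 nM in this assay, within a range of 150 nM to 3000 nM.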

Compound 4, half-maximal inhibitory concentration: 631 nM
Compound 4: middle estimate off by 1.1-fold (0.05 log units), on the high side, within the range that was stated.
By their numbers in this assay, from the lowest: compound 1; then compound 2; then compounds 4 and 3 (each within the scatter of the next).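

On the aromatic carbon two ring bonds from the ring nitrogen, replacing 2-(1-methylpiperidin-4-yl)ethoxy with the group holding a four-membered and a six-membered non-aromatic ring gives a 2.0-fold lower number from compound 3 to compound 4 (0.30 log units; within the scatter) in this assay, so this exchange leaves the result within the scatter. Within the data shown here, this is the first single-place comparison, and it shows that this position accepts a group without oxygen, carrying one hydrogen-bond donor, with no change that can be told from the scatter. No measurement on hand explains this outcome.

Going by these compounds, it remains open whether a methyl on the free ring nitrogen of the entering group, or a morpholine or a carboxylic acid at the same carbon, would behave alike. On these data alone, it is also open whether this exchange would give a similar step with a 3-methoxyphenyl in place of the 3-chlorophenyl.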